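This account rests on a few compounds, and the source may have more. Where it says the series, first, only, none or still open, it means among the compounds named here.

Compound 1, `CSc1ccc(CNc2nc(SC)nc3ncccc23)cc1`, was tested in a functional assay on MCF7 cells (Homo sapiens) for cytotoxicity, read by MTT assay, with a stated time of 72 h (a higher number here means a weaker inhibitor of growth, a lower number a stronger inhibitor of growth), where compound 1 gives 50 nM. Two relatives built on a different core were measured in this assay as well: compound 2, `COc1ccc(CNc2nc([SeH])nc3ccccc23)cc1`, gives 42700 nM, and compound 3, `CSc1ccc(CNc2nc([SeH])nc3ccccc23)cc1`, gives 48100 nM. Among these three, compound 1 has the lowest number by a wide margin. How the core of compound 1 differs from the core of compound 3 is not broken down here. Compound 3 and compound 2 differ in one place only: methoxy in place of methylsulfanyl on an aromatic carbon. That change produced a step of a 1.1-fold lower number from compound 3 to compound 2 (0.05 log units; within the scatter).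

Compound 4, `COc1ccc(CNc2nc(SC)nc3ncccc23)cc1`, has not yet been measured. It carries the core of compound 1 and differs from compound 1 in one place: methoxy in place of methylsulfanyl on an aromatic carbon. This is the same change that turned compound 3 into compound 2, and the place is described in the same words, so a step of the same kind, and of similar small size, is expected. In this assay the expected step is a 1.0-fold lower number from compound 1 to compound 4 (0.02 log units; within the scatter), which rests on the earlier step of a 1.1-fold lower number from compound 3 to compound 2 (0.05 log units; within the scatter). Compound 4 is therefore expected to give about 48 nM in this assay, most likely between 16 nM and 150 nM.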

Compound 4, concentration for 50% growth inhibition: 48100 nM
Compound 4: the middle estimate sits 1000-fold (3.00 log units) below what was measured, outside the stated range (above it).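

In this assay, replacing methylsulfanyl with methoxy on the core of compound 1 has a large effect, with a 960-fold higher number from compound 1 to compound 4 (2.98 log units; beyond the scatter). Set beside the same change on the other core, the two steps do not agree: the same change on two cores in this assay, a 1.1-fold lower number (0.05 log units; within the scatter) from compound 3 to compound 2 and a 960-fold higher number (2.98 log units; beyond the scatter) from compound 1 to compound 4, 1100-fold (3.03 log units) apart, beyond the scatter of two such steps This shows that in this series the size of the step depends on the core carrying it, so a small step on one core gives no safe estimate for another; it does not show which structural difference between the cores matters, or why the change has such a large effect on only one of them, and it rests on a single pair for each core.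

The compounds shown leave open how other groups in the same place, such as a chlorine atom, an amine or a longer chain like ethylsulfanyl, would behave on the core of compound 1. They also leave open whether the low number of compound 1 is specific to methylsulfanyl or would be shared by other groups there.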